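Removing a methoxy and methylating the amine: compound 4

The source may report more compounds than this note shows. Statements on the series, on what has been measured and on what is new or still open speak of the compounds shown alone.

Compound 1, `COc1ccc(CNCCCNS(=O)(=O)c2cc(C(F)(F)F)cc(C(F)(F)F)c2)cc1OC`, gives 18000 nM in a functional assay on PANC-1 cells (Homo sapiens) for inhibition, read by MTT assay, with a stated time of 72 h; a higher number here means a weaker inhibitor of growth, a lower number a stronger inhibitor of growth.
Compound 2, `COc1cccc(CNCCCNS(=O)(=O)c2cc(C(F)(F)F)cc(C(F)(F)F)c2)c1`, gives 10000 nM.
Compound 3, `O=S(=O)(NCCCNCc1ccc(Cl)c(C(F)(F)F)c1)c1cc(C(F)(F)F)cc(C(F)(F)F)c1`, gives 10000 nM.

All three share the same core, a sulfonamide linked through a short saturated chain to an amine bearing a benzyl-type group, and all three are weak inhibitors of growth. Compound 2 stands level with compound 3, the two lowest numbers: no change at the digits printed from compound 2 to compound 3 (within the scatter). Against compound 1 it reads lower, a 1.8-fold lower number from compound 1 to compound 2 (0.26 log units; within the scatter), but this too is within the scatter, so none of the three can be ranked against another.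

Compound 4, `CN(CCCNS(=O)(=O)c1cc(C(F)(F)F)cc(C(F)(F)F)c1)Cc1ccccc1`, is not yet measured. Its change from compound 2 is benzyl(methyl)amino in place of (3-methoxybenzyl)amino on a saturated chain carbon, three bonds along the chain from a sulfonamide nitrogen. The methoxy is gone and the amine carries a methyl where a hydrogen stood.

Within the data shown here, two measured steps bear on this. Taking a methoxy off the ring, a 1.8-fold lower number from compound 1 to compound 2 (0.26 log units; within the scatter), moved nothing beyond the scatter, and swapping the entire aryl group, no change at the digits printed from compound 2 to compound 3 (within the scatter), moved nothing either. Among the measured compounds shown here, no measured pair tests a methyl on the amine, so that part stands untested. The expected step is therefore a 1.2-fold higher number from compound 2 to compound 4 (0.08 log units; within the scatter), no shift beyond the scatter. Compound 4 is estimated at 12000 nM, with a range from 4000 nM to 40000 nM.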

Compound 4, concentration for 50% growth inhibition: > 50000 nM
Compound 4 gave a limit, no number; the forecaster's own chance of this, stated with the estimate: 20%; middle value at least 4.1-fold (0.61 log units) from the limit.
By their numbers in this assay, from the lowest: compounds 2, 3 and 1 (each within the scatter of the next). At a limit, above all of these: compound 4.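

In this assay, among these compounds, the change at this saturated chain carbon, three bonds along the chain from a sulfonamide nitrogen, gives an at least 5.0-fold higher number from compound 2 to compound 4 (0.69 log units; beyond the scatter), the only step so far that passes the scatter. Among compounds 1, 2 and 3, which all keep a hydrogen on the amine, changes to the aryl group left the numbers within the scatter, whereas this change, which also replaces that hydrogen with a methyl, shows that growth inhibition in this series can respond to what stands at this position. The entry for compound 4 is a limit and not a number, so the step has a known minimum but no known size: the limit of > 50000 nM in this assay, at which 1 of the 4 values shown sits.

The step combines two edits, the loss of the methoxy and the methyl on the amine, and the compounds shown cannot separate them: benzylamino would carry only the first edit, and (3-methoxybenzyl)(methyl)amino only the second. Also open, from the compounds shown here alone, is how an ethyl on the same amine, or a longer chain in place of the present one, would read in this assay.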